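Pyridin-2-yl to pyridin-4-yl: working notes on the series

The source may report more compounds than this note shows. Statements on the series, on what has been measured and on what is new or still open speak of the compounds shown alone.

Measured so far in a physicochemical assay for solubility, in phosphate buffer, with a stated time of 18 h; a lower number here means a less soluble compound, a higher number a more soluble compound:
- compound 1 `CSc1nc(C(C)(C)C)nc2nc(N)c(C#N)c(N)c12`: 14000 nM
- compound 2 `CC(C)(C)c1nc(-c2ccccn2)c2c(N)c(C#N)c(N)nc2n1`: 87000 nM

Of these two compounds, compound 2 holds the higher number, at 87000 nM. The next compound to consider is compound 3 `CC(C)(C)c1nc(-c2ccncc2)c2c(N)c(C#N)c(N)nc2n1`, which carries pyridin-4-yl in place of pyridin-2-yl on an aromatic carbon. The two compounds have the same atoms, joined differently.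

Going by the values given here, the only measured step that bears on this change is a 6.2-fold higher number from compound 1 to compound 2 (0.79 log units; beyond the scatter). It is modest in size and replaces methylsulfanyl with pyridin-2-yl, so it is a different kind of change. Among the compounds with values here, no measured compound carries pyridin-4-yl, and no pair of pyridine isomers has been compared. That step therefore serves only as a rough upper guide to size. In this assay, a smaller step is expected, most likely within the scatter and with no firm direction. The expected step is a 1.2-fold lower number from compound 2 to compound 3 (0.09 log units; within the scatter). Compound 3 is estimated at 70000 nM, with an expected range of 25000 nM to 180000 nM.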

Compound 3, solubility: 44000 nM
Beside the measured number, compound 3's estimate is 1.6-fold (0.20 log units) above it; the range from low to high includes it.
By their numbers in this assay, from the lowest: compound 1; then compounds 3 and 2 (each within the scatter of the next).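

In this assay, moving the ring nitrogen from pyridin-2-yl to pyridin-4-yl gives a 2.0-fold lower number from compound 2 to compound 3 (0.30 log units; within the scatter) and this lies within the scatter, so the two pyridine isomers are not separated at this aromatic carbon, and the placement of the ring nitrogen has no resolved effect on this read-out. The gain over methylsulfanyl is no longer tied to a single isomer: alongside a 6.2-fold higher number from compound 1 to compound 2 (0.79 log units; beyond the scatter) there now stands a 3.1-fold higher number from compound 1 to compound 3 (0.50 log units; beyond the scatter) and both steps lie beyond the scatter, with no listed pyridine going against this, though only these two pyridines and this one core are covered. Nothing available explains either the gain over methylsulfanyl or the lack of separation between the isomers.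

Still open, on these data alone, is what pyridin-3-yl, a plain phenyl ring or a saturated amine such as morpholine would give on this same aromatic carbon, and so whether the gain belongs to pyridines in particular or to replacing methylsulfanyl more generally. Also open, as far as these compounds go, is whether the pyridine isomers stay this close when a group such as cyclopropyl stands in place of the tert-butyl group.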